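Fluoro on the anilino ring of compound 3

The compounds below may be only part of what the source reports. "The series", "measured", "known", "first", "only" and "open" are said of these compounds alone.

In a functional assay on HCC827 cells (Homo sapiens) for antiproliferative activity, read by MTT assay, with a stated time of 72 h (on this read-out lower numbers stand for stronger inhibition and higher numbers for weaker inhibition), compound 3 (`CN1CCN(c2ccc(Nc3ncc4nc(Nc5ccccc5)n([C@H]5CCN(S(=O)(=O)C6CC6)C5)c4n3)cc2)CC1`) gives 1.6 nM, the lowest number of the three measured. Compound 1 (`CN1CCN(c2ccc(Nc3ncc4nc(Nc5ccc(F)cc5)n([C@H]5CCCN(S(=O)(=O)C6CC6)C5)c4n3)cc2)CC1`) gives 8.6 nM and compound 2 (`CN1CCN(c2ccc(Nc3ncc4nc(Nc5ccc(F)cc5)n([C@H]5CCNC5)c4n3)cc2)CC1`) gives 1220 nM. Compound 4 (`CN1CCN(c2ccc(Nc3ncc4nc(Nc5ccc(F)cc5)n([C@H]5CCN(S(=O)(=O)C6CC6)C5)c4n3)cc2)CC1`) changes phenyl to 4-fluorophenyl: fluoro in place of hydrogen on an aromatic carbon. For the measured compounds named here, no measured step isolates this change. Going by the values given here, the one available step, a 140-fold higher number from compound 1 to compound 2 (2.15 log units; beyond the scatter), is large but lies on the aromatic nitrogen, and both of its compounds carry 4-fluorophenyl. Compound 1 carries that group and still gives 8.6 nM, although it also differs from compound 3 on the aromatic nitrogen. No step beyond the scatter is therefore expected, and the estimated step is a 1.8-fold higher number from compound 3 to compound 4 (0.24 log units; within the scatter). The estimate for compound 4 is 2.8 nM, with an expected range of 0.9 nM to 9 nM.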

Compound 4, half-maximal inhibitory concentration: 7.5 nM
Estimate against measurement, compound 4: 2.7-fold (0.43 log units) below, within the range that was stated.
By their numbers in this assay, from the lowest: compound 3; then compounds 4 and 1 (each within the scatter of the next); then compound 2.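

Fluoro in place of hydrogen at this position of the anilino ring is not neutral in this assay: the isolated step is a 4.7-fold higher number from compound 3 to compound 4 (0.67 log units; beyond the scatter) and gives a weaker result. With fluoro present, the sulfonyl group has a far larger effect (a 160-fold lower number from compound 2 to compound 4 (2.21 log units; beyond the scatter)), while the pyrrolidine and piperidine forms are not separated (a 1.1-fold lower number from compound 1 to compound 4 (0.06 log units; within the scatter)). Nothing available explains the fluoro step. Going by these compounds, it remains open whether the loss is specific to fluoro or extends to chloro, methoxy or an amine at the same place.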